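Little to go on: a first nitro chalcone estimate

The source may report more compounds than this note shows. Statements on the series, on what has been measured and on what is new or still open speak of the compounds shown alone.

Compound 1 `COc1cc(OC)c(OC)cc1/C=C/C(=O)c1ccccc1`: > 150000 nM (a limit)
Compound 2 `COc1cc(OC)c(OC)cc1/C=C/C(=O)c1ccc(O)cc1`: 155000 nM

Within the data shown here, in a functional assay on SW982 cells (Homo sapiens) for inhibition, read by MTT assay, with a stated time of 72 h (a higher number here means a weaker inhibitor, a lower number a stronger inhibitor), compound 2 gives 155000 nM, the only actual number so far. For compound 1, > 150000 nM is a limit and not a number. Among the measured compounds shown here, the one measured step, a step that the limit leaves unreadable from compound 1 to compound 2, puts hydroxy in place of hydrogen, and it offers no size to build on because of the limit of > 150000 nM in this assay, at which 1 of the 2 values shown sits.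

Compound 3 `COc1cc(OC)c(OC)cc1/C=C/C(=O)c1ccc([N+](=O)[O-])cc1` differs from compound 2 in one place: nitro in place of hydroxy on an aromatic carbon. No measured step sizes this change, so no shift beyond the usual scatter is expected in this assay, in either direction. this assay could also report only a limit for compound 3.

The estimated change is a 1.3-fold lower number from compound 2 to compound 3 (0.11 log units; within the scatter). The expected value for compound 3 is 120000 nM, with an estimated range of 35000 nM to 220000 nM.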

Compound 3, half-maximal inhibitory concentration: > 150000 nM
Compound 3 gave a limit, no number; the forecaster's own chance of this, stated with the estimate: 35%; at least 1.2-fold (0.09 log units) between middle value and limit.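

Compound 3 gives only a limit in this assay, so no step from compound 1 or compound 2 to compound 3 can be read: the limit of > 150000 nM in this assay, at which 2 of the 3 values shown sit.

The compounds shown leave open whether hydrogen, hydroxy or nitro at this place differ at all in this assay.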